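Swapping Ethoxy for Methoxy: Expected Cytotoxicity of Compound 4

The source may hold more compounds than are shown below. What is called first, only, known or untested is meant among the compounds shown, and "the series" means these compounds.

Measured compounds:
compound 1 `CCOC(=O)c1c(-c2ccc(OC)cc2)oc2ccc(OCCCN3C(=O)/C(=N\OC)c4ccccc43)cc12`: 128 ug/mL
compound 2 `CCO/N=C1\C(=O)N(CCCOc2ccc3oc(-c4ccc(OC)cc4)c(C(=O)OCC)c3c2)c2ccccc21`: 16 ug/mL
compound 3 `CCO/N=C1\C(=O)N(CCCCOc2ccc3oc(-c4ccc(OC)cc4)c(C(=O)OCC)c3c2)c2ccccc21`: 64 ug/mL

In an ADME assay on Vero cells (Chlorocebus sabaeus) for cytotoxicity, read by MTT assay, with a stated time of 72 h (on this read-out lower numbers stand for higher toxicity in this test and higher numbers for lower toxicity in this test), compound 1 gives 128 ug/mL, compound 2 gives 16 ug/mL and compound 3 gives 64 ug/mL. Compound 4 `CCOC(=O)c1c(-c2ccc(OC)cc2)oc2ccc(OCCCCN3C(=O)/C(=N\OC)c4ccccc43)cc12` has not yet been measured. It differs from compound 3 by hydrogen in place of methyl on a saturated chain carbon bound to an oxygen on an unsaturated carbon. The same change separates compound 2 from compound 1, namely (hydrogen in place of methyl on a saturated chain carbon bound to an oxygen on an unsaturated carbon), and there it produced an 8.0-fold higher number from compound 2 to compound 1 (0.90 log units; beyond the scatter). The difference between the cores of compound 2 and compound 3 is not broken down here. Since the place of the change is worded identically in both pairs, this is the same change. For compound 4 a step of about a 4.0-fold higher number from compound 3 to compound 4 (0.60 log units; beyond the scatter) in this assay is expected, because the earlier pair showed an 8.0-fold higher number from compound 2 to compound 1 (0.90 log units; beyond the scatter). Compound 4 is therefore estimated at 256 ug/mL, expected to fall between 100 ug/mL and 700 ug/mL.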

Compound 4, half-maximal cytotoxic concentration: 32 ug/mL
Beside the measured number, compound 4's estimate is 8.0-fold (0.90 log units) above it; measured number outside the range, below it.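

In this assay, replacing ethoxy with methoxy gave a 2.0-fold lower number from compound 3 to compound 4 (0.30 log units; within the scatter), so on this core the swap left no clear mark on the read-out. Set beside the earlier pair, the result does not agree with it: the same change on two cores in this assay, an 8.0-fold higher number (0.90 log units; beyond the scatter) from compound 2 to compound 1 and a 2.0-fold lower number (0.30 log units; within the scatter) from compound 3 to compound 4, 16-fold (1.20 log units) apart, beyond the scatter of two such steps. This shows that the size of the step seen on one core cannot simply be carried over to the other core in this series, although it does not show why the two cores differ or what the swap would do on any further core.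

The compounds shown leave open what a longer chain, such as propoxy, would do in place of the ethoxy group. They also leave open the effect of a chain ending in an amine.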